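The source may report more compounds than this note shows. Statements on the series, on what has been measured and on what is new or still open speak of the compounds shown alone.

Measured in a functional assay on MDA-MB-231 cells (Homo sapiens) for cytotoxicity, read by MTT assay, with a stated time of 72 h; a higher number here means a weaker inhibitor, a lower number a stronger inhibitor:
- compound 1 `CCN(CC)Cc1ccc2nc(NC(=O)N/N=C/c3cn(Cc4ccc(Cl)cc4Cl)c4ccccc34)sc2c1`: 3280 nM
- compound 2 `CCN(CC)Cc1ccc2nc(NC(=O)N/N=C/c3cn(Cc4ccc(Cl)cc4)c4ccccc34)sc2c1`: 2570 nM
- compound 3 `CCN(CC)Cc1ccc2nc(NC(=O)N/N=C/c3c[nH]c4ccccc34)sc2c1`: 1900 nM

Compound 3, at 1900 nM, lies within the scatter of both compound 1 and compound 2, so these three values cannot be ordered.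

Compound 4 `CCN(CC)Cc1ccc2nc(NC(=O)N/N=C/c3cn(Cc4ccccc4Cl)c4ccccc34)sc2c1` has 2-chlorobenzyl in place of hydrogen on an aromatic nitrogen of compound 3: 2-chlorobenzyl in place of hydrogen on an aromatic nitrogen. Two measured steps make the same kind of exchange in the opposite direction, replacing a chlorinated benzyl group with hydrogen on that nitrogen: a 1.4-fold lower number from compound 2 to compound 3 (0.13 log units; within the scatter) and a 1.7-fold lower number from compound 1 to compound 3 (0.24 log units; within the scatter). Both stay within the scatter, as does the loss of a chloro from the benzyl group, a 1.3-fold lower number from compound 1 to compound 2 (0.11 log units; within the scatter). Among the measured compounds shown here, the 2-chlorobenzyl group itself has no measured precedent in this set, so the expectation rests on these close analogues. No step beyond the scatter is therefore expected in this assay.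

The estimated change is a 1.4-fold higher number from compound 3 to compound 4 (0.15 log units; within the scatter).

For compound 4 the estimate is 2700 nM, with an expected range of 1500 nM to 4800 nM.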

Compound 4, half-maximal inhibitory concentration: 900 nM
Beside the measured number, compound 4's estimate is 3.0-fold (0.48 log units) above it; measured number outside the range, below it.
By their numbers in this assay, from the lowest: compound 4; then compounds 3, 2 and 1 (each within the scatter of the next).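

In this assay, a substituent on the aromatic nitrogen now separates from hydrogen: 2-chlorobenzyl gives a 2.1-fold lower number from compound 3 to compound 4 (0.32 log units; beyond the scatter) as a step beyond the scatter, which neither the 4-chlorobenzyl of compound 2 nor the 2,4-dichlorobenzyl of compound 1 did. The chloro pattern on the benzyl group therefore counts, with a 2.9-fold lower number from compound 2 to compound 4 (0.46 log units; beyond the scatter) on exchanging 4-chlorophenyl for 2-chlorophenyl and a 3.6-fold lower number from compound 1 to compound 4 (0.56 log units; beyond the scatter) on replacing one chloro of the dichloro group with hydrogen, and compound 1 goes against any rule that a 2-chloro alone is enough. No measurement available here accounts for this difference.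

Still open, as far as these compounds go, is whether unsubstituted benzyl on this nitrogen would fall with compound 3 or with compound 4. Also open, from the compounds shown here alone, is whether 2-fluorobenzyl or 2-methoxybenzyl would keep the step seen with 2-chlorobenzyl.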